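The source may hold more compounds than are shown below. What is called first, only, known or untested is meant among the compounds shown, and "the series" means these compounds.

Measured in a functional assay on SMMC-7721 cells (Homo sapiens) for antiproliferative activity, read by MTT assay, with a stated time of 72 h; on this read-out lower numbers stand for stronger inhibition and higher numbers for weaker inhibition:
compound 1 `CN(C(=O)c1ccccc1)c1ccc2[nH]c(-c3n[nH]c4ccccc34)cc2n1` gives 12500 nM;
compound 2 `CN(C(=O)c1ccc(Cl)cc1)c1ccc2[nH]c(-c3n[nH]c4ccccc34)cc2n1` gives 2420 nM;
compound 3 `CN(c1ccc2[nH]c(-c3n[nH]c4ccccc34)cc2n1)S(=O)(=O)c1ccc(Cl)cc1` gives 12700 nM.

Compound 3 carries the highest number of the three. Against compound 1 the gap is within the scatter: a 1.0-fold higher number from compound 1 to compound 3 (0.01 log units; within the scatter). Against compound 2 it is beyond it: a 5.2-fold higher number from compound 2 to compound 3 (0.72 log units; beyond the scatter). The remaining step in the set, a 5.2-fold lower number from compound 1 to compound 2 (0.71 log units; beyond the scatter), is a substituent change on the benzoyl group.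

Compound 4 `CN(c1ccc2[nH]c(-c3n[nH]c4ccccc34)cc2n1)S(=O)(=O)c1cccc([N+](=O)[O-])c1` differs from compound 3 in one place: 3-nitrophenyl in place of 4-chlorophenyl on a sulfonyl sulfur. Among the compounds with values here, no measured step alters the aryl group on a sulfonyl sulfur. Within the data shown here, the only substituent change in the set, a 5.2-fold lower number from compound 1 to compound 2 (0.71 log units; beyond the scatter), sits on a benzoyl group rather than on a sulfonyl, so it bears on compound 4 only loosely, and the sulfonyl-bearing compound 3 sits with compound 1 at the weak end of the series. With nothing in the set that ties a nitrophenyl group on a sulfonyl to a shift in this assay, no step beyond the scatter is expected from compound 3 to compound 4: a 1.1-fold lower number from compound 3 to compound 4 (0.02 log units; within the scatter). Compound 4 is accordingly estimated at 12000 nM, with a range of 4000 nM to 40000 nM.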

Compound 4, half-maximal inhibitory concentration: 5070 nM
For compound 4 the middle estimate is 2.4-fold (0.37 log units) above the measured one, within the range that was stated.
By their numbers in this assay, from the lowest: compound 2; then compound 4; then compounds 1 and 3 (each within the scatter of the next).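

In this assay, the aryl group on a sulfonyl sulfur proves to be a position that responds: 3-nitrophenyl in place of 4-chlorophenyl gives a 2.5-fold lower number from compound 3 to compound 4 (0.40 log units; beyond the scatter), a modest step but beyond the scatter. The sulfonyl link therefore does not by itself fix a compound at the level of compound 3 at 12700 nM, since the aryl group on the sulfur also moves the number, with compound 4 at 5070 nM. No measurement of any property of these compounds is available to account for this step.

This single step exchanges both the substituent and its place on the ring, so the compounds shown cannot separate the effect of nitro replacing chloro from that of the new ring position. Also open, on these data alone, are how an unsubstituted phenyl on the sulfonyl sulfur, or a phenyl carrying an amine or a methoxy group, would read in this assay, and whether 3-nitrophenyl would shift the number in the same direction on a carbonyl in place of the sulfonyl.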